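This account rests on a few compounds, and the source may have more. Where it says the series, first, only, none or still open, it means among the compounds named here.

Compound 1 `CC(C(=O)NCc1ccc(C(F)(F)F)cc1N1CCC(C)(C)CC1)c1ccc(NS(C)(=O)=O)c(F)c1`: 1.3 nM
Compound 2 `CC(C(=O)NCc1ccc(C(F)(F)F)cc1Cl)c1ccc(NS(C)(=O)=O)c(F)c1`: 4 nM

In an assay on CHO cells for antagonist activity at transient receptor potential cation channel subfamily V member 1 (Homo sapiens), read by FLIPR (on this read-out higher numbers stand for weaker inhibition and lower numbers for stronger inhibition), compound 2 gives the higher of the two numbers and compound 1 the lower. Among the compounds with values here, the one measured step, a 3.1-fold higher number from compound 1 to compound 2 (0.49 log units; beyond the scatter), put chloro in place of 4,4-dimethylpiperidin-1-yl on the aromatic carbon. Compound 3 `CCCCCc1cc(C(F)(F)F)ccc1CNC(=O)C(C)c1ccc(NS(C)(=O)=O)c(F)c1` is not yet measured; it carries pentyl in place of chloro on an aromatic carbon. Pentyl reoccupies that aromatic carbon, so a step in this assay toward a lower number of roughly that size, or none beyond the scatter, is expected. The estimate for compound 3 is 2 nM, with a range of 0.7 nM to 6 nM. The expected step is a 2.0-fold lower number from compound 2 to compound 3 (0.30 log units; within the scatter).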

Compound 3, inhibition constant: 0.4 nM
Beside the measured number, compound 3's estimate is 5.0-fold (0.70 log units) above it; measured number below the stated range.
By their numbers in this assay, from the lowest: compound 3; then compound 1; then compound 2.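

At this aromatic carbon, ortho to a large group and meta to a trifluoromethyl group, this assay records a 10-fold lower number from compound 2 to compound 3 (1.00 log units; beyond the scatter) and a 3.3-fold lower number from compound 1 to compound 3 (0.51 log units; beyond the scatter). The larger of the two earlier substituents gave the lower number, but a ring is not required at this position: pentyl, with no ring, gives the lowest number of the three. No measurement on hand accounts for these steps.

Going by these compounds, whether a shorter chain such as propyl or a longer chain such as octyl would give a lower or higher number stays open. So does the effect of an amine at the end of the pentyl chain.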